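The source may report more compounds than this note shows. Statements on the series, on what has been measured and on what is new or still open speak of the compounds shown alone.

Compound 2 `CCS(=O)(=O)N1CCC([C@@H](C)n2c(C)c(C(=O)NCc3c(OC)cc(C)[nH]c3=O)c3ccccc32)CC1` gives 80 nM in an assay on HeLa cells for inhibition of histone-lysine N-methyltransferase EZH2 (Homo sapiens), read by AlphaLISA, with a stated time of 72 h; a higher number here means that more compound is needed for the effect, a lower number that less compound is needed. Among the compounds with values here, compound 1 `COc1cc(C)[nH]c(=O)c1CNC(=O)c1c(C)n([C@H](C)C2CCN(C(=O)OC(C)C)CC2)c2ccccc12` gives 110 nM in this assay; the single step between them, a 1.4-fold lower number from compound 1 to compound 2 (0.14 log units; within the scatter), swaps the group at the same amine nitrogen in a ring. Compound 2 therefore stands at the lower of the two numbers, a gap within the scatter. Compound 3 `CCOC(=O)CN1CCC([C@@H](C)n2c(C)c(C(=O)NCc3c(OC)cc(C)[nH]c3=O)c3ccccc32)CC1` differs from compound 2 by (ethoxycarbonyl)methyl in place of ethylsulfonyl on an amine nitrogen in a ring. Within the data shown here, the only measured step bearing on this position, a 1.4-fold lower number from compound 1 to compound 2 (0.14 log units; within the scatter), stayed within the scatter, so in this assay no step beyond the scatter is expected: a 1.4-fold higher number from compound 2 to compound 3 (0.14 log units; within the scatter). For compound 3 the estimated value is 110 nM, with a range from 40 nM to 300 nM.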

Compound 3, half-maximal effective concentration: 260 nM
The estimate for compound 3 lay 2.4-fold (0.37 log units) below the measured number; measured number inside the range.
By their numbers in this assay, from the lowest: compounds 2 and 1 (each within the scatter of the next); then compound 3.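

The group on the amine nitrogen in the ring does move the number in this assay: (ethoxycarbonyl)methyl brings a 3.3-fold higher number from compound 2 to compound 3 (0.51 log units; beyond the scatter) when it replaces ethylsulfonyl and a 2.4-fold higher number from compound 1 to compound 3 (0.37 log units; beyond the scatter) when it replaces isopropoxycarbonyl. Within the data shown here, both steps are modest, but they are the first at this position to lie beyond the scatter, which the earlier step did not show. No measurement at hand bears on why the number rises. Still open, from the compounds shown here alone, is how a carboxylic acid in place of the ester in (ethoxycarbonyl)methyl, or a longer chain on the same nitrogen, would read.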